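A Larger Hydroxylated Ring in Place of the Cyclobutylmethyl

This account rests on a few compounds, and the source may have more. Where it says the series, first, only, none or still open, it means among the compounds named here.

Compound 1 `N#Cc1cnc(NCc2cnccc2C(F)(F)F)cc1NC[C@H]1C[C@@H](O)C1` was tested in an assay on isolated protein for inhibition of protein kinase C delta type (Homo sapiens), read by TR-FRET, with a stated time of 2 h (on this read-out lower numbers stand for stronger inhibition and higher numbers for weaker inhibition), and gives 4200 nM; it is the only compound of this small set for which a number rather than a limit is shown. Compound 2 `N#Cc1cnc(NCc2ccccc2C(F)(F)F)cc1N[C@H]1CC[C@H](O)CC1` reaches only a limit in this assay, > 10000 nM. the limit of > 10000 nM in this assay, at which 1 of the 2 values shown sits, describes that outcome.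

Compound 3 `CC1(C)C[C@@H](Nc2cc(NCc3cnccc3C(F)(F)F)ncc2C#N)CC[C@@H]1O` differs from compound 1 by 4-hydroxy-3,3-dimethylcyclohexyl in place of (3-hydroxycyclobutyl)methyl on a nitrogen on an aromatic ring. Going by the values given here, no step between two measured compounds is available to gauge what such a change does in this assay, so the expectation rests on compound 1 alone. A step of moderate size toward stronger inhibition is expected, a 2.1-fold lower number from compound 1 to compound 3 (0.32 log units; beyond the scatter), though it could as well stay within the usual scatter. For compound 3 the estimated value in this assay is 2000 nM, with a range from 400 nM to 10000 nM.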

Compound 3, half-maximal inhibitory concentration: 2400 nM
Compound 3: the middle estimate sits 1.2-fold (0.08 log units) below what was measured, and the stated range covers the measured number.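

With the change on the nitrogen on the aromatic ring, this assay shows a 1.8-fold lower number from compound 1 to compound 3 (0.24 log units; within the scatter) and so no shift that can be told apart from repeat measurement. This position therefore takes 4-hydroxy-3,3-dimethylcyclohexyl, with its six-membered ring and 9 heavy atoms, in place of (3-hydroxycyclobutyl)methyl, with its four-membered ring and 6 heavy atoms, and the read-out stays in the same range. Nothing measured here gives a reason for this outcome.

On these data alone, it remains open whether the larger ring or the 3,3-dimethyl substitution matters more, as this single step changes both at once. Also open, as far as these compounds go, is how an amine or a carboxylic acid in place of the hydroxyl on this ring would read in this assay at this position.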